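Swapping Bromo for Carbamoyl on an Aniline Acid Series

The compounds below may be only part of what the source reports. "The series", "measured", "known", "first", "only" and "open" are said of these compounds alone.

Within the data shown here, compound 1 `O=C(O)CCc1ccc(NCc2cccc(Br)c2)cc1` gives 120% in a functional assay on CHO cells for agonist activity at Free fatty acid receptor 1 (Homo sapiens), read by reporter gene assay (on this read-out lower numbers stand for smaller maximal responses and higher numbers for larger maximal responses), the higher of the two numbers measured so far. Compound 2 `O=C(O)CCc1ccc(NCc2ccc(O)cc2)cc1` gives 37% in this assay, which stands well below compound 1, beyond the usual scatter. Compound 3 `NC(=O)c1cccc(CNc2ccc(CCC(=O)O)cc2)c1` has not yet been measured; it differs from compound 1 by carbamoyl in place of bromo on an aromatic carbon. Since compound 2 carries a polar group on the same outer ring and gives 37%, a drop is expected for compound 3 as well, though a milder one, estimated as a number 55 percentage points lower from compound 1 to compound 3 (beyond the scatter). Compound 3 is thus expected to reach about 65%, with a likely range from 30% to 105%.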

Compound 3, largest response reached (reported as percent of maximum), in percent of the reference or control that the assay uses: 18%
Beside the measured number, compound 3's estimate is 47 percentage points above it, and the stated range ends above it.
By their numbers in this assay, from the lowest: compound 3; then compound 2; then compound 1.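

In this assay, among these compounds, carbamoyl in place of bromo gives a number 102 percentage points lower from compound 1 to compound 3 (beyond the scatter), the first measured step in which only one place changes. It shows that the group on this aromatic carbon, meta to a large group, can by itself decide much of the maximal response while the rest of compound 1 stays the same. Nothing measured here explains the loss. Still open, on these data alone, is whether a nitrile or a methoxy group at this same place would keep the response, or whether chlorine would serve as well as bromo.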